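The compounds below may be only part of what the source reports. "The series", "measured", "known", "first", "only" and "open" are said of these compounds alone.

Compound 1 `COC(=O)c1c[nH]c2cc(OCCOc3ccccc3)ccc2c1=O` gives > 20000 nM in an ADME assay on J774 cells (Mus musculus) for cytotoxicity (a lower number here means that less compound is needed, a higher number that more compound is needed for the effect), which is a limit of the assay rather than a number.
Compound 2 `CCCCc1cc2c(=O)c(C(=O)OCC)c[nH]c2cc1OCCOc1ccccc1` gives > 20000 nM, again a limit.
Compound 3 `COC(=O)c1c[nH]c2ccc(Cl)cc2c1=O` gives > 20000 nM, also a limit.

Compound 2 therefore stands at the limit of > 20000 nM in this assay, at which 3 of the 3 values shown sit, and nothing in these three values sets it apart from the others. For the measured compounds named here, no pair of measured compounds differs in a single place, so no measured step shows how any change moves the number.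

Compound 4 `CCCCc1cc2c(=O)c(C(=O)NC(C)C)c[nH]c2cc1OCCOc1ccccc1` differs from compound 2 by isopropylamino in place of ethoxy on a carbonyl carbon. Going by the values given here, with no measured step to lean on, the step that the limit leaves unreadable from compound 2 to compound 4 is expected to be none beyond the scatter. Compound 4 is thus estimated at 30000 nM, with a range from 10000 nM to 100000 nM, most likely reported again only as a limit.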

Compound 4, half-maximal effective concentration: > 20000 nM
Compound 4: a limit, no number (the forecaster's own chance of this, stated with the estimate: 80%); the middle value does not contradict the limit.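

For the compounds shown here, compound 2 and compound 4 both stand only at a limit in this assay, so no step between them can be read. The compounds shown leave open whether isopropylamino in place of ethoxy changes the effect at all.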